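The source may hold more compounds than are shown below. What is called first, only, known or untested is meant among the compounds shown, and "the series" means these compounds.

Measured so far in a toxicity assay on the whole organism with Rattus norvegicus as the target, at a dose of 400 mg/kg by the oral route; on this read-out higher numbers stand for a stronger effect at the one dose given and lower numbers for a weaker effect:
- compound 1 `Brc1ccccc1OCC1=NCCO1`: 100%
- compound 2 `Cc1ccccc1OCC1=NCCO1`: 100%
- compound 3 `Clc1ccccc1OCC1=NCCO1`: 60%

Compound 3 stands lowest of the three numbers. Both steps that lead to it are beyond the scatter: a number 40 percentage points lower from compound 1 to compound 3 (beyond the scatter) and a number 40 percentage points lower from compound 2 to compound 3 (beyond the scatter), whereas no change at the digits printed from compound 1 to compound 2 (within the scatter).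

Next in line is compound 4 `O=[N+]([O-])c1ccccc1OCC1=NCCO1`. Against compound 3 the change is nitro in place of chloro on an aromatic carbon. Within the data shown here, no measured step exchanges chloro for nitro, so nothing bears directly on it. The two steps ending at compound 3 were large and both downward on reaching chloro; leaving chloro again makes a move back toward the higher numbers of compound 1 and compound 2 plausible, but the size is open and a step within the scatter cannot be excluded.

For compound 4 the expected step in this assay is a number 20 percentage points higher from compound 3 to compound 4 (beyond the scatter). Compound 4 is thus estimated at 80%, with a range from 40% to 100%.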

Compound 4, a percentage reported as activity, at one dose (the size of the read-out at that dose, not a potency): 90%
The estimate for compound 4 lay 10 percentage points below the measured number; measured number inside the range.
By their numbers in this assay, from the lowest: compound 3; then compounds 4, 1 and 2 (each within the scatter of the next).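

At this position in this assay, the chloro result does not extend to a larger group: nitro gives a number 30 percentage points higher from compound 3 to compound 4 (beyond the scatter). Nitro also stays within the scatter of the other two groups, with a number 10 percentage points lower from compound 2 to compound 4 (within the scatter) and a number 10 percentage points lower from compound 1 to compound 4 (within the scatter), so among these four compounds chloro alone stands apart. Nothing available explains this difference. Still open, as far as these compounds go, is whether an amine or a carboxylic acid on the same aromatic carbon would stay with the higher numbers or fall toward chloro. Also open, from the compounds shown here alone, is whether fluoro would follow chloro.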